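A few compounds are considered here, and "the series" means these few. Any claim that something is new, unique, unknown or untested is made for them only; others in the source may bear on it.

Compound 1 `Fc1ccc2nc(-c3cncnc3)n(C3CC3)c2c1` gives 5380 nM in an ADME assay on cells for inhibition of cytochrome P450 11B1, mitochondrial (Homo sapiens), read by HPLC, with a stated time of 60 min; on this read-out higher numbers stand for weaker inhibition and lower numbers for stronger inhibition. Compound 2 `Fc1ccc2nc(-c3cnccn3)n(C3CC3)c2c1` reaches only the limit of this assay, reported as > 10000 nM. Compound 3 `Fc1cc2nc(-c3cncnc3)n(C3CC3)c2cc1F` gives 2270 nM in this assay.

Compound 3 holds the lowest of the two numbers given here; its nearest neighbour is compound 1, and the step of a 2.4-fold lower number from compound 1 to compound 3 (0.37 log units; beyond the scatter) is modest though beyond the scatter. The other measured step, an at least 1.8-fold higher number from compound 1 to compound 2 (0.26 log units; that floor lies within the scatter), ends at the limit of > 10000 nM in this assay, at which 1 of the 3 values shown sits. Compound 4 `Fc1cc2nc(-c3cncnc3C3CC3)n(C3CC3)c2cc1F` differs from compound 3 by cyclopropyl in place of hydrogen on an aromatic carbon. Neither measured step puts a cyclopropyl in place of hydrogen, so none bears directly on this change. Compound 4 is therefore expected to move little, with an expected step of a 1.1-fold higher number from compound 3 to compound 4 (0.04 log units; within the scatter) inside the scatter. Compound 4 is estimated at 2500 nM, between 800 nM and 8000 nM.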

Compound 4, half-maximal inhibitory concentration: > 10000 nM
Compound 4 gave a limit, no number; the forecaster's own chance of this, stated with the estimate: 15%; middle value at least 4.0-fold (0.60 log units) away from the limit.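

In this assay, cyclopropyl in place of hydrogen on this aromatic carbon, next to the ring nitrogen and ortho to a large group, gives an at least 4.4-fold higher number from compound 3 to compound 4 (0.64 log units; beyond the scatter), so this position is not indifferent to the change. The earlier compounds shown here showed no change at this carbon. Compound 4 stands at a limit rather than a number, so its step is only a floor, and it shares that limit with compound 2: the limit of > 10000 nM in this assay, at which 2 of the 4 values shown sit.

From the compounds shown here alone, whether a methyl or an amine on this same carbon would keep the number of compound 3 remains open. Also open, going by these compounds, is whether cyclopropyl here would raise the number on the core of compound 1.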